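Urea-amide series: where compound 4 is expected to fall

The source may report more compounds than this note shows. Statements on the series, on what has been measured and on what is new or still open speak of the compounds shown alone.

Compound 2 `Cc1ccc(NC(=O)Nc2cccc(Cl)c2)cc1NC(=O)c1cnoc1C` and compound 1 `Cc1ccc(NC(=O)Nc2ccccc2F)cc1NC(=O)c1cnoc1C` share one core. In a functional assay on U-937 cells (Homo sapiens) for antiproliferative activity, read by MTT assay, with a stated time of 24 h (on this read-out lower numbers stand for stronger inhibition of growth and higher numbers for weaker inhibition of growth), compound 2 gives > 30000 nM, which is a limit of the assay rather than a number. Compound 1 also sits at a limit in this assay, giving > 30000 nM. The change between them, (2-fluorophenyl in place of 3-chlorophenyl on an amide-type nitrogen), yields a step that the two limits leave unreadable from compound 2 to compound 1, consistent with the limit of > 30000 nM in this assay, at which 3 of the 3 values shown sit. Compound 3 `Cc1cc(NC(=O)Nc2cccc(Cl)c2)ccc1NC(=O)c1cnoc1C` has the same atoms as compound 2 joined differently; the difference between the two cores is not broken down here. In this assay compound 3 gives > 30000 nM, again a limit. Compound 4 `Cc1cc(NC(=O)Nc2ccccc2F)ccc1NC(=O)c1cnoc1C` is the not yet measured partner, differing from compound 3 by 2-fluorophenyl in place of 3-chlorophenyl on an amide-type nitrogen, the same change as from compound 2 to compound 1. For the measured compounds named here, the step is expected to be a step that the limit leaves unreadable from compound 3 to compound 4 because the limit of > 30000 nM in this assay, at which 3 of the 3 values shown sit, holds every measured value so far. Compound 4 is therefore expected to give about 40000 nM in this assay, most probably reported again only as a limit.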

Compound 4, concentration for 50% growth inhibition: > 30000 nM
Compound 4 ended at the assay's limit; the forecaster's own chance of this, stated with the estimate: 85%; the middle value does not contradict the limit.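

For the compounds shown here, compound 3 and compound 4 both sit at a limit, so no step between them can be read: the limit of > 30000 nM in this assay, at which 4 of the 4 values shown sit. The compounds shown leave open whether 2-fluorophenyl and 3-chlorophenyl differ at all in this assay.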